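The source may report more compounds than this note shows. Statements on the series, on what has been measured and on what is new or still open speak of the compounds shown alone.

compound 1 `CCCCCCCCCCCCCCNC(=O)[C@H](CO)NCc1ccccc1OC`: 100000 nM
compound 2 `CCCCCCCCCCCCCCNC(=O)[C@H](CO)/N=C/c1cccc(Cl)c1`: 24100 nM

For the measured compounds named here, in a functional assay on cells (Homo sapiens) for cytotoxicity, read by MTT assay, with a stated time of 24 h (on this read-out lower numbers stand for stronger inhibition and higher numbers for weaker inhibition), compound 2 gives 24100 nM, the lower of the two numbers so far. Compound 1 gives 100000 nM.

The next compound is compound 3 `CCCCCCCCCCCCCCNC(=O)[C@H](CO)/N=C/c1ccccc1C`. Its difference from compound 2 is 2-methylphenyl in place of 3-chlorophenyl on a carbon with a double bond to nitrogen.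

Going by the values given here, only one measured step exists, a 4.1-fold lower number from compound 1 to compound 2 (0.62 log units; beyond the scatter). It is modest, and it exchanges a whole group on a saturated chain carbon bound to a carbonyl carbon and a saturated chain carbon. It therefore offers only a loose guide. Among the compounds with values here, no measured pair exchanges only the group on the carbon with a double bond to nitrogen, so the direction of this change is not established by the data. Since the change in compound 3 is narrower than the one in a 4.1-fold lower number from compound 1 to compound 2 (0.62 log units; beyond the scatter), a smaller step is expected, probably within the scatter.

The estimated step is a 1.2-fold higher number from compound 2 to compound 3 (0.10 log units; within the scatter).

For compound 3 the expected value is 30000 nM, with an estimated range of 12000 nM to 80000 nM.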

Compound 3, half-maximal inhibitory concentration: 87700 nM
The estimate for compound 3 lay 2.9-fold (0.47 log units) below the measured number; the whole stated range lies below it.
By their numbers in this assay, from the lowest: compound 2; then compounds 3 and 1 (each within the scatter of the next).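

In this assay, for the compounds shown here, the group on a carbon with a double bond to nitrogen clearly matters: 2-methylphenyl in place of 3-chlorophenyl gives a 3.6-fold higher number from compound 2 to compound 3 (0.56 log units; beyond the scatter), the first measured exchange confined to this place and a step beyond the scatter. The double bond to nitrogen does not by itself go with the lower number, as compound 3 carries it too, yet a 1.1-fold lower number from compound 1 to compound 3 (0.06 log units; within the scatter) lies within the scatter, whereas a 4.1-fold lower number from compound 1 to compound 2 (0.62 log units; beyond the scatter) lies beyond it; among these three compounds, the 3-chlorophenyl compound alone stands apart. No measurement on hand accounts for the step at this position.

The exchange alters the substituent and its ring number together, so the chlorine-for-methyl change cannot be separated from the change of ring number; 3-methylphenyl and 2-chlorophenyl would divide the two. Going by these compounds, whether a 3-bromophenyl group on the same carbon would extend the lower number of compound 2, and whether the step between these two groups would persist with a shorter chain on the amide nitrogen, remain open.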